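Shortening a Diamine Chain and Adding Chlorine

The source may hold more compounds than are shown below. What is called first, only, known or untested is meant among the compounds shown, and "the series" means these compounds.

For the measured compounds named here, compound 2 `Cc1csc2cc([C@H](C)Nc3ncnc(N)c3C#N)c(-c3cccc(CN(C)CCCCN(C)Cc4ccccc4)c3)c(=O)n12` is one of three compounds measured in a physicochemical assay for acid dissociation. In this assay compound 2 gives 7, the second highest of the three numbers. Compound 1 `Cc1csc2cc([C@H](C)Nc3ncnc(N)c3C#N)c(-c3cccc(CN4CCC(N(C)CC(C)C)CC4)c3)c(=O)n12` gives 6.8, which lies within the scatter of compound 2. Compound 3 `Cc1csc2cc([C@H](C)Nc3ncnc(N)c3C#N)c(-c3cccc(CN4CCC(CN(C)CC(C)C)CC4)c3)c(=O)n12` gives 8, a gap from compound 2 that lies beyond the scatter. Going by the values given here, the only step between measured compounds that differ in one place is a number 1.20 log units higher from compound 1 to compound 3 (beyond the scatter), a large change.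

Compound 4 `Cc1csc2cc([C@H](C)Nc3ncnc(N)c3C#N)c(-c3cccc(CN(C)CCCN(C)Cc4ccc(Cl)cc4)c3)c(=O)n12` has not been measured. It differs from compound 2 by (4-chlorobenzyl)(methyl)amino in place of (benzyl(methyl)amino)methyl on a saturated chain carbon, three bonds along the chain from an amine nitrogen. Cut one bond further out, the same difference reads 3-(benzyl(methyl)amino)propyl to 2-((4-chlorobenzyl)(methyl)amino)ethyl, so the chain between the two amine nitrogens becomes shorter and the outer ring gains a chlorine. The step of a number 1.20 log units higher from compound 1 to compound 3 (beyond the scatter) is the only measured one in which the separation of the two amine nitrogens changes, and compound 4 moves in the opposite direction, bringing them closer. A downward step is therefore expected for compound 4, estimated as a number 0.40 log units lower from compound 2 to compound 4 (beyond the scatter), smaller than a number 1.20 log units higher from compound 1 to compound 3 (beyond the scatter). For compound 4 the expected value in this assay is 6.6, with a range from 6.2 to 7.1.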

Compound 4, acid dissociation constant: 7.5
Estimate against measurement, compound 4: 0.90 log units below; measured number outside the range, above it.
By their numbers in this assay, from the lowest: compounds 1 and 2 (each within the scatter of the next); then compound 4; then compound 3.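

In this assay the change at this saturated chain carbon, three bonds along the chain from an amine nitrogen, gives a number 0.50 log units higher from compound 2 to compound 4 (beyond the scatter) and so shows that shortening the chain while adding a chlorine to the outer ring does not lower the number here. That step runs the same way as a number 1.20 log units higher from compound 1 to compound 3 (beyond the scatter) even though the two amine nitrogens move apart in that earlier step and closer together in this one, so among these compounds the separation of the nitrogens alone does not set the direction of the number. No measurement shown here accounts for the rise.

Going by these compounds, the shorter chain and the chlorine arrive together in compound 4, so their separate shares of the step remain unknown. A compound with the shorter chain and an unsubstituted benzyl group would pull the two apart, and a fluorine or a methoxy group in place of the chlorine would show whether the substituent on the outer ring matters at all.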